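From 8-carboxyoctyl to carboxy on compound 2

The source may hold more compounds than are shown below. What is called first, only, known or untested is meant among the compounds shown, and "the series" means these compounds.

Measured compounds, by half-maximal cytotoxic concentration:
Compound 1 `CCCCCCCCCCCCCC(=O)NC(CO[C@@H]1O[C@H](CO)[C@H](O)[C@H](O)[C@H]1O)C(=O)NCCOS(=O)(=O)O` gives > 100000 nM
Compound 2 `CCCCCCCCCCCCCCNC(=O)C(CO[C@@H]1O[C@H](CO)[C@H](O)[C@H](O)[C@H]1O)NC(=O)CCCCCCCCCCC(=O)O` gives > 100000 nM
Compound 3 `CCCCCCCCCCCCCC(=O)NC(CO[C@@H]1O[C@H](CO)[C@H](O)[C@H](O)[C@H]1O)C(=O)NCCO` gives > 100000 nM

In a functional assay on CEM-SS cells (Homo sapiens) for cytotoxicity (a lower number here means that less compound is tolerated, a higher number that more compound is tolerated), compound 2 stands at > 100000 nM and this is a limit of the assay, not a number. For the measured compounds named here, the whole set looks alike on this point, with the limit of > 100000 nM in this assay, at which 3 of the 3 values shown sit, as the common reading, so no compound can be ranked against another.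

The change from compound 2 to compound 4 `CCCCCCCCCCCCCCNC(=O)C(CO[C@@H]1O[C@H](CO)[C@H](O)[C@H](O)[C@H]1O)NC(=O)CCC(=O)O` lies in one place, where carboxy takes the place of 8-carboxyoctyl on a saturated chain carbon, two bonds along the chain from a carbonyl carbon (carboxy in place of 8-carboxyoctyl on a saturated chain carbon, two bonds along the chain from a carbonyl carbon). Going by the values given here, the only measured step, a step that the two limits leave unreadable from compound 1 to compound 3 concerns a different change, hydrogen in place of sulfo, and offers no size to carry over.

With compound 2 at > 100000 nM as the starting point, again a limit, no step beyond the scatter is expected in this assay and no direction can be favoured. The expected step is a number no higher from compound 2 to compound 4 (the limit leaves the size open) and it is only an estimate. The estimate for compound 4 is 100000 nM with an expected range from 50000 nM to 200000 nM and the assay may well report only a limit again.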

Compound 4, half-maximal cytotoxic concentration: > 100000 nM
Compound 4 gave a limit, no number; the forecaster's own chance of this, stated with the estimate: 90%; the middle value sits exactly at the limit.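

In this assay compound 4 gives > 100000 nM, which is a limit of the assay and not a number. Compound 2 also rests on a limit, so the step between the two cannot be read. The compounds shown leave open at what concentration any of them harms these cells, and whether replacing 8-carboxyoctyl with carboxy changes that concentration.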